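Halogen changes on the benzamide arm of the shared core

A few compounds are considered here, and "the series" means these few. Any claim that something is new, unique, unknown or untested is made for them only; others in the source may bear on it.

Of the compounds shown here, two have numbers so far. In a functional assay on SK-BR-3 cells (Homo sapiens) for antiproliferative activity, read by MTT assay, with a stated time of 72 h (on this read-out lower numbers stand for stronger inhibition and higher numbers for weaker inhibition), compound 1 `CCN1CCN(c2cc(C)c3cc(NC(=O)c4cccc(Cl)c4)ccc3n2)CC1` gives 17800 nM, and compound 2 `CCN1CCN(c2cc(C)c3cc(NC(=O)c4cccc(F)c4)ccc3n2)CC1` gives 24900 nM. Among the compounds with values here, the single step between them, a 1.4-fold higher number from compound 1 to compound 2 (0.15 log units; within the scatter), leaves the pair indistinguishable. Compound 2 thus stands at the higher of the two numbers, though its gap to compound 1 is within the scatter.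

Compound 3 `CCN1CCN(c2cc(C)c3cc(NC(=O)c4ccc(Cl)c(Cl)c4)ccc3n2)CC1` is not yet measured in this assay. It differs from compound 2 by 3,4-dichlorophenyl in place of 3-fluorophenyl on a carbonyl carbon. Within the data shown here, the only measured step that bears on this is the change of chloro to fluoro between compound 1 and compound 2, which ran within the scatter; reversing it should give back roughly the number of compound 1, while the second chlorine has no precedent. For compound 3 the expected step is a 2.1-fold lower number from compound 2 to compound 3 (0.32 log units; beyond the scatter), a modest move toward a lower number that may not clear the scatter. The estimate for compound 3 in this assay is 12000 nM, with a range from 4000 nM to 35000 nM.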

Compound 3, half-maximal inhibitory concentration: 2160 nM
Compound 3: middle estimate off by 5.6-fold (0.74 log units), on the high side; measured number below the stated range.
By their numbers in this assay, from the lowest: compound 3; then compounds 1 and 2 (each within the scatter of the next).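

In this assay, within the data shown here, the aryl group on the carbonyl carbon shows a clear response for the first time: chloro in place of hydrogen on an aromatic carbon gives an 8.2-fold lower number from compound 1 to compound 3 (0.92 log units; beyond the scatter) while the exchange of one halogen for another gave a 1.4-fold higher number from compound 1 to compound 2 (0.15 log units; within the scatter) and so left the pair apart by no more than the scatter. Among these compounds, the wider change of 3,4-dichlorophenyl in place of 3-fluorophenyl gives a 12-fold lower number from compound 2 to compound 3 (1.06 log units; beyond the scatter) and is the largest step so far. Compound 3 therefore stands apart from both earlier compounds, which remain within the scatter of each other, and among these three compounds adding a chloro moved the number where swapping one halogen for another did not. Nothing at hand speaks to the reason for these steps.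

Still open, from the compounds shown here alone, is whether a methyl, a methoxy or a trifluoromethyl group in place of the added chloro would give a step of similar size. Also open, going by these compounds, is whether the step holds when the ethyl group on the shared core gives way to a longer chain.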